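A Second Chloro Group Added to Compound 2

This account rests on a few compounds, and the source may have more. Where it says the series, first, only, none or still open, it means among the compounds named here.

Of the compounds shown here, two have been measured so far. Compound 1 `N#C/C(=C\N1CCN(C(=O)c2ccco2)C1=S)C(=O)Nc1ccc(Cl)cc1` and compound 2 `O=CN1CCN(c2ccc(Cl)cc2)C1=S` were both tested in a functional assay on BT-549 cells (Homo sapiens) for inhibition, read by sulforhodamine B assay, with a stated time of 48 h; a higher number here means a weaker inhibitor of growth, a lower number a stronger inhibitor of growth. In this assay compound 1 gives 8600 nM. In the same assay compound 2 gives 25400 nM, the highest of the two numbers; its nearest neighbour, compound 1, sits at a lower number, and the gap between the two lies beyond the usual scatter. The two compounds differ in more than one place, so their values are simply recorded side by side and no single change is held responsible for the gap.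

Compound 3 `O=CN1CCN(c2ccc(Cl)c(Cl)c2)C1=S` has not yet been measured in this assay. It differs from compound 2 by chloro in place of hydrogen on an aromatic carbon, the incoming chloro group standing ortho to the chloro group already present. For the measured compounds named here, no measured pair in this set shows the effect of such an addition, so the direction is open. The expected step is a 1.4-fold lower number from compound 2 to compound 3 (0.15 log units; within the scatter), judged to lie within the usual scatter. Compound 3 is accordingly estimated at 18000 nM, with a range from 7000 nM to 45000 nM.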

Compound 3, concentration for 50% growth inhibition: 18000 nM
Beside the measured number, compound 3's estimate shows no gap at the digits printed; the range from low to high includes it.
By their numbers in this assay, from the lowest: compound 1; then compounds 3 and 2 (each within the scatter of the next).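

In this assay, for the compounds shown here, chloro in place of hydrogen on an aromatic carbon, ortho to a chloro group and meta to a group of 8 heavy atoms, gives a 1.4-fold lower number from compound 2 to compound 3 (0.15 log units; within the scatter), and this is the first comparison in the set in which only one place differs. It shows that this position of the six-membered aromatic ring can carry a second chloro group with no difference from the hydrogen of compound 2 that stands beyond the scatter, so the two compounds cannot be put in order by this read-out. Nothing available explains this outcome.

The compounds shown leave open whether another group at this same position, such as an amine, a methoxy group or a carboxylic acid, would give a step beyond the scatter. They also leave open what the same addition would do in the setting of compound 1, which differs from compound 3 in more than one place and so cannot be set against it as a single change.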